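Swapping the side chain of compound 3 for a carbamoyl group

The source may hold more compounds than are shown below. What is called first, only, known or untested is meant among the compounds shown, and "the series" means these compounds.

Measured compounds:
compound 1 `CSCC[C@H](NC(=O)CN(c1ncnc2c1ncn2C1CCCCO1)C1CC1)C(=O)OCc1ccccc1` 42.7%
compound 2 `O=C(CN(c1ncnc2c1ncn2C1CCCCO1)C1CC1)NCC(=O)OCc1ccccc1` 25.9%
compound 3 `O=C(CN(c1ncnc2c1ncn2C1CCCCO1)C1CC1)N[C@@H](CCC(=O)OCc1ccccc1)C(=O)OCc1ccccc1` 25.2%

In a functional assay on the whole organism (Tail, strain ICR) with Mus musculus as the target, in the tail flick test, with a stated time of 90 min, at a dose of 25 umol/kg by the oral route (on this read-out higher numbers stand for a stronger effect at the one dose given and lower numbers for a weaker effect), compound 3 gives the lowest of the three numbers, but its step of a number 0.7 percentage points lower from compound 2 to compound 3 (within the scatter) lies within the scatter, so compound 2 and compound 3 read alike. Only compound 1 stands apart, with a number 17.5 percentage points lower from compound 1 to compound 3 (beyond the scatter) and a number 16.8 percentage points lower from compound 1 to compound 2 (beyond the scatter) both beyond the scatter.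

Compound 4 `NC(=O)C[C@H](NC(=O)CN(c1ncnc2c1ncn2C1CCCCO1)C1CC1)C(=O)OCc1ccccc1` differs from compound 3 by carbamoyl in place of (benzyloxycarbonyl)methyl on a saturated chain carbon, two bonds along the chain from an amide-type nitrogen and a carbonyl carbon. Within the data shown here, no measured step makes exactly this change. The closest guides are the steps at the same chain carbon: a number 0.7 percentage points lower from compound 2 to compound 3 (within the scatter) shows that adding a side chain left the number unchanged, while a number 16.8 percentage points lower from compound 1 to compound 2 (beyond the scatter) shows that the chain with methylsulfanyl mattered. With one step flat and one modest, the expected step is a number 2.8 percentage points higher from compound 3 to compound 4 (within the scatter), none beyond the scatter. Compound 4 is therefore estimated at 28%, within a range from 12% to 45%.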

Compound 4, a percentage reported as activity, at one dose (the size of the read-out at that dose, not a potency): 35%
The estimate for compound 4 lay 7 percentage points below the measured number; the measured number falls inside the stated range.
By their numbers in this assay, from the lowest: compounds 3, 2, 4 and 1 (each within the scatter of the next, the first and the last beyond it).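

In this assay the steps of a number 9.8 percentage points higher from compound 3 to compound 4 (within the scatter) and a number 9.1 percentage points higher from compound 2 to compound 4 (within the scatter) and a number 7.7 percentage points lower from compound 1 to compound 4 (within the scatter) all lie within the scatter, so compound 4 reads alike with each earlier compound. At this chain carbon, (benzyloxycarbonyl)methyl, with its six-membered aromatic ring, can therefore give way to carbamoyl, which has no ring, without a change beyond the scatter. Compound 4 also blurs the earlier picture of compound 1 standing apart: compound 1 and compound 3 remain separated beyond the scatter, but compound 4 sits within the scatter of both.

The compounds shown leave open how a carboxylic acid or an amine at the end of this side chain would read. Nothing available gives a measured reason for these numbers.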